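Replacing phenylcarbamoyl with 4-methyl-2-oxopyrrolidin-1-yl

This account rests on a few compounds, and the source may have more. Where it says the series, first, only, none or still open, it means among the compounds named here.

Measured in a physicochemical assay for lipophilicity, using the shake flask method, in phosphate buffer, measured as octanol-water partition, with a stated time of 30 min, at pH 7.4; a lower number here means a more polar compound, a higher number a more lipophilic compound:
Compound 1 `O=C(Nc1ccccc1)c1cnc(NCc2c(F)ccc3c2CCO3)n2cnnc12` gives 4.1
Compound 2 `Cn1cc(-c2cnc(NCc3c(F)ccc4c3CCO4)c3cn[nH]c(=O)c23)cn1` gives 2.7
Compound 3 `Cn1nccc1-c1cnc(NCc2c(F)ccc3c2CCO3)c2cn[nH]c(=O)c12` gives 2.6

In this assay, compound 1 holds the highest of the three numbers, and the values of compound 2 and compound 3 both lie beyond the scatter from it. Compound 4 `C[C@@H]1CC(=O)N(c2cnc(NCc3c(F)ccc4c3CCO4)n3cnnc23)C1` has not yet been measured. It departs from compound 1 by one change on an aromatic carbon of the shared core: 4-methyl-2-oxopyrrolidin-1-yl in place of phenylcarbamoyl on an aromatic carbon.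

Going by the values given here, only one measured step exists, a number 0.10 log units lower from compound 2 to compound 3 (within the scatter). It exchanges one methylpyrazole for another on a core other than that of compound 1, so it gives no direct size for this replacement. Among the compounds with values here, no measured pair shows phenylcarbamoyl leaving. The estimate therefore rests on the structural change alone, with its smaller group and no six-membered aromatic ring of carbon only, and it is correspondingly wide. The expected step is downward and beyond the scatter, a number 1.20 log units lower from compound 1 to compound 4 (beyond the scatter). For compound 4 the estimated value is 2.9, with an expected range from 2.3 to 3.5.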

Compound 4, distribution coefficient: 1.8
Compound 4: middle estimate off by 1.10 log units, on the high side; measured number outside the range, below it.
By their numbers in this assay, from the lowest: compound 4; then compounds 3 and 2 (each within the scatter of the next); then compound 1.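

Going by these compounds alone, replacing phenylcarbamoyl with 4-methyl-2-oxopyrrolidin-1-yl on this aromatic carbon of the shared core gives, in this assay, a number 2.30 log units lower from compound 1 to compound 4 (beyond the scatter), the first sign that a change at this position can move the read-out so far. Within the data shown here, the single earlier step, an exchange of one methylpyrazole for another on a different core, could not show this. The change takes away the six-membered aromatic ring of carbon only and the hydrogen-bond donor and brings in a smaller group with a five-membered non-aromatic ring, but no information here links the step to any of these differences.

The compounds shown leave open how an amine, a carboxylic acid or a simple acetamide on this aromatic carbon would read. They also leave open whether the other configuration of the defined stereocentre would give a different number.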